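Trifluoromethyl on the benzylsulfanyl group of compound 2

The source may hold more compounds than are shown below. What is called first, only, known or untested is meant among the compounds shown, and "the series" means these compounds.

- compound 1 `Cc1cc(Nc2ccc(C(=O)/C=C/c3ccc4ccccc4c3)cc2)n2nc(SCc3cccc(Br)c3)nc2n1`: 270 nM
- compound 2 `Cc1cc(Nc2ccc(C(=O)/C=C/c3ccc4ccccc4c3)cc2)n2nc(SCc3ccccc3)nc2n1`: 300 nM

In a functional assay on SW-620 cells (Homo sapiens) for cytotoxicity, read by MTT assay, with stated times of 4 h and 72 h, tested at 5 uM (on this read-out lower numbers stand for stronger inhibition and higher numbers for weaker inhibition), compound 2 at 300 nM lies within the scatter of compound 1 at 270 nM, so the two values give no order. Compound 3 `Cc1cc(Nc2ccc(C(=O)/C=C/c3ccc4ccccc4c3)cc2)n2nc(SCc3cccc(C(F)(F)F)c3)nc2n1` is compound 2 with trifluoromethyl in place of hydrogen on an aromatic carbon, meta to a large group (trifluoromethyl in place of hydrogen on an aromatic carbon). The benzylsulfanyl group thus becomes (3-(trifluoromethyl)benzyl)sulfanyl. Among the compounds with values here, the only measured step that bears on this change is a 1.1-fold higher number from compound 1 to compound 2 (0.05 log units; within the scatter), with hydrogen in place of bromo on an aromatic carbon. Within the data shown here, no measured compound carries trifluoromethyl, so this single step gives only a weak guide. No change beyond the scatter is therefore expected in this assay, and no direction is favoured. The expected step is a 1.1-fold lower number from compound 2 to compound 3 (0.03 log units; within the scatter). For compound 3 the estimated value is 280 nM, with an expected range of 130 nM to 600 nM.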

Compound 3, half-maximal inhibitory concentration: 2070 nM
The estimate for compound 3 lay 7.4-fold (0.87 log units) below the measured number; measured number outside the range, above it.
By their numbers in this assay, from the lowest: compounds 1 and 2 (each within the scatter of the next); then compound 3.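

In this assay this place on the benzyl ring, meta to a large group, is no longer indifferent to its substituent: the step is a 6.9-fold higher number from compound 2 to compound 3 (0.84 log units; beyond the scatter) and lies beyond the scatter, whereas a 1.1-fold higher number from compound 1 to compound 2 (0.05 log units; within the scatter) gave no order between bromo and hydrogen. Trifluoromethyl also separates from bromo at the same place, with a 7.7-fold higher number from compound 1 to compound 3 (0.88 log units; beyond the scatter) as the step, so the tolerance seen for bromo does not extend to every group placed there. Nothing available on these compounds accounts for this separation.

Going by these compounds, whether the higher number follows trifluoromethyl alone stays open; a methyl, a methoxy or a nitrile at this same place would test that. The compounds shown also leave open whether the step holds in cells other than these.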